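This account rests on a few compounds, and the source may have more. Where it says the series, first, only, none or still open, it means among the compounds named here.

Measured in a functional assay on HCC827 cells (Homo sapiens) for cytotoxicity, read by MTT assay, with a stated time of 72 h; on this read-out lower numbers stand for stronger inhibition and higher numbers for weaker inhibition:
compound 1 `CC(C)n1c(Nc2ccccc2)nc2cnc(Nc3ccc(N4CCN(C)CC4)cc3)nc21`: 0.1 nM
compound 2 `Cc1cc(C)cc(-n2c(Nc3ccccc3)nc3cnc(Nc4ccc(N5CCN(C)CC5)cc4)nc32)c1`: 1 nM
compound 3 `CC1CCN(c2ccc(Nc3ncc4nc(Nc5ccccc5)n(C5CCCC5)c4n3)cc2)CC1`: 32 nM

Of the three, compound 3 has the highest number in this assay, at 32 nM. Compound 4 `c1ccc(Nc2ncc3nc(Nc4ccccc4)n(C4CCCC4)c3n2)cc1` differs from it in one place: hydrogen in place of 4-methylpiperidin-1-yl on an aromatic carbon. In words, hydrogen stands in place of 4-methylpiperidin-1-yl on an aromatic carbon. Within the data shown here, no measured step covers this change. The only one available, a 10-fold higher number from compound 1 to compound 2 (1.00 log units; beyond the scatter), concerns a group on an aromatic nitrogen and bears on it only indirectly. Among the measured compounds shown here, with that step as the sole guide to size, a shift of similar size is expected, toward a higher number, although no measurement establishes that direction. The estimated change is a 10-fold higher number from compound 3 to compound 4 (1.00 log units; beyond the scatter). For compound 4 the expected value is 320 nM, with an estimated range from 50 nM to 3000 nM.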

Compound 4, half-maximal inhibitory concentration: 2.7 nM
Estimate against measurement, compound 4: 120-fold (2.07 log units) above; measured number below the stated range.
By their numbers in this assay, from the lowest: compound 1; then compound 2; then compound 4; then compound 3.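

In this assay, hydrogen in place of 4-methylpiperidin-1-yl on an aromatic carbon gives a 12-fold lower number from compound 3 to compound 4 (1.07 log units; beyond the scatter), the first change shown at this position. A low number here therefore needs no large group on this aromatic carbon, and the 4-methylpiperidin-1-yl group is worse than none. Nothing available accounts for this shift. Going by these compounds, it remains open whether a morpholine or a methoxy group on this carbon would sit nearer to hydrogen or to 4-methylpiperidin-1-yl. On these data alone, it is also open whether hydrogen would give a similar step with isopropyl on the aromatic nitrogen.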